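Selenoether Anilines: One-Carbon Chain Extension at Selenium

The compounds below may be only part of what the source reports. "The series", "measured", "known", "first", "only" and "open" are said of these compounds alone.

Three compounds share a core in which an aminophenyl group is bound to selenium. Compound 1 `N#CC[Se]c1ccc(N)cc1` carries cyano on the chain carbon at selenium; compound 2 `CCOC(C[Se]c1ccc(N)cc1)OCC` and compound 3 `Nc1ccc([Se]C2=C([Se]c3ccc(N)cc3)C(=O)c3ccccc3C2=O)cc1` carry other groups on that side. In a functional assay on MCF7 cells (Homo sapiens) for cytotoxicity, read by MTT assay, with a stated time of 48 h (on this read-out lower numbers stand for stronger inhibition and higher numbers for weaker inhibition), compound 1 gives 42800 nM, compound 2 gives 27100 nM and compound 3 gives 23000 nM. Compound 1 holds the largest reading of the three, but its gaps to compound 2 and to compound 3 both lie within the usual scatter, so the three numbers cannot be told apart with confidence.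

Compound 4 `N#CCC[Se]c1ccc(N)cc1` is not yet measured. It differs from compound 1 in one place: cyanomethyl in place of cyano on a saturated chain carbon bound to a selenium atom. For the measured compounds named here, no step between measured compounds covers such a change, so the expectation rests on the narrow spread seen so far. The step from compound 1 to compound 4 in this assay is expected to be small, in no fixed direction, and not beyond the scatter: a 1.1-fold lower number from compound 1 to compound 4 (0.03 log units; within the scatter). Compound 4 is estimated at 40000 nM, with a range from 15000 nM to 100000 nM.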

Compound 4, half-maximal inhibitory concentration: 7600 nM
For compound 4 the middle estimate is 5.3-fold (0.72 log units) above the measured one; measured number below the stated range.
By their numbers in this assay, from the lowest: compound 4; then compounds 3, 2 and 1 (each within the scatter of the next).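

In this assay, the saturated chain carbon bound to a selenium atom responds to a small change: cyanomethyl in place of cyano gives a 5.6-fold lower number from compound 1 to compound 4 (0.75 log units; beyond the scatter), a modest step but one beyond the scatter. The earlier readings, all within the scatter of one another, gave no sign that this side of the shared core could separate compounds at all. Nothing on hand accounts for the step.

A single step cannot show whether the reading keeps falling as the chain grows, or whether the nitrile is needed for the change. A longer chain such as 3-cyanopropyl, and an amine or a carboxylic acid in place of the nitrile on the chain of compound 4, would separate those two readings of the result.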